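This account rests on a few compounds, and the source may have more. Where it says the series, first, only, none or still open, it means among the compounds named here.

Two measured compounds share one core. Compound 1 `COc1cccc(Cc2cc(-c3cccs3)nn(CC(=O)Nc3ccc(F)cc3)c2=O)c1` and compound 2 `Cc1cc(Cc2cccc(Br)c2)c(=O)n(CC(=O)Nc2ccc(Br)cc2)n1` were both tested in a functional assay on HL-60 cells (Homo sapiens), read by calcium flux; a lower number here means that less compound is needed, a higher number that more compound is needed for the effect. For compound 1 the result is only a limit of the assay, > 50000 nM. For compound 2 the result is likewise only a limit, > 50000 nM. Among the measured compounds shown here, both values thus sit at the limit of > 50000 nM in this assay, at which 2 of the 2 values shown sit, so compound 2 stands exactly where the only other measured compound stands, with no number of its own. Compound 3 `Cc1cc(Cc2ccsc2)c(=O)n(CC(=O)Nc2ccc(Br)cc2)n1` has not yet been measured. It differs from compound 2 in one place: thiophen-3-yl in place of 3-bromophenyl on a saturated chain carbon bound to an aromatic carbon. For the measured compounds named here, no measured pair shows what this exchange does, so there is no step to build on. Because both known values sit at the limit of > 50000 nM in this assay, at which 2 of the 2 values shown sit, the step that the limit leaves unreadable from compound 2 to compound 3 is expected to be none beyond the scatter. The estimate for compound 3 in this assay is therefore 60000 nM, expected to fall between 20000 nM and 200000 nM, most likely again as a limit rather than a number.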

Compound 3, half-maximal effective concentration: > 50000 nM
Compound 3 was reported as a limit; the forecaster's own chance of this, stated with the estimate: 80%; the middle value is on the limit's open side.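

In this assay, among the compounds shown here, compound 2 and compound 3 both end at a limit rather than a number, so no step between them can be read: the limit of > 50000 nM in this assay, at which 3 of the 3 values shown sit.

The compounds shown leave open how thiophen-3-yl and 3-bromophenyl compare, and whether any change on the shared core gives a readable number in this assay.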